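The source may report more compounds than this note shows. Statements on the series, on what has been measured and on what is new or still open speak of the compounds shown alone.

Of the compounds shown here, two built on one shared core have been measured in a functional assay on SF-295 cells (Homo sapiens) for inhibition, read by sulforhodamine B assay, with a stated time of 48 h, tested at 100 uM; on this read-out lower numbers stand for a stronger effect and higher numbers for a weaker effect at the one concentration tested. Compound 1 `COc1cc(Cl)cc(-c2nn(-c3cccc(NC(=O)Nc4cc(C(F)(F)F)cc(C(F)(F)F)c4)c3)cc2-c2ccncc2)c1` gives -63% in this assay. Compound 2 `COc1cc(Cl)cc(-c2nn(-c3cccc(NC(=O)Nc4ccc(Cl)c(Cl)c4)c3)cc2-c2ccncc2)c1` gives -21% in this assay, the higher of the two numbers and so the weaker effect; its gap to compound 1 lies beyond the usual scatter of repeated measurements. Compound 3 `COc1cc(Cl)cc(-c2nn(-c3cccc(NC(=O)Nc4cccc(C(F)(F)F)c4)c3)cc2-c2ccncc2)c1` has not yet been measured. It differs from compound 2 in a single place: 3-(trifluoromethyl)phenyl in place of 3,4-dichlorophenyl on an amide-type nitrogen. Among the measured compounds shown here, no measured pair shows this exact exchange, so its effect can only be guessed from the two readings at hand. The gap between compound 1 and compound 2, which also differ in the group on this amide-type nitrogen, shows that a change at this place can move the reading well beyond the scatter. For the step from compound 2 to compound 3 a move toward a lower number, beyond the scatter, is expected, as a number 19 percentage points lower from compound 2 to compound 3 (beyond the scatter). Compound 3 is accordingly estimated to give -40% in this assay, within a range from -70% to -5%.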

Compound 3, a percentage reported as activity, at one concentration (the size of the read-out at that concentration, not a potency): -53%
Estimate against measurement, compound 3: 13 percentage points above; the measured number falls inside the stated range.
By their numbers in this assay, from the lowest: compounds 1 and 3 (each within the scatter of the next); then compound 2.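

Taken in this assay, the exchange of 3,4-dichlorophenyl for 3-(trifluoromethyl)phenyl on the amide-type nitrogen gives a number 32 percentage points lower from compound 2 to compound 3 (beyond the scatter), so the group at this position can change the reading substantially even when the rest of the molecule stays the same. The second step isolates one group on that ring: hydrogen in place of trifluoromethyl on an aromatic carbon gives a number 10 percentage points higher from compound 1 to compound 3 (within the scatter), which means that in this assay a ring with one trifluoromethyl group cannot be told apart from a ring with two. No supporting data on these compounds explain why the two rings on this nitrogen give different readings.

Going by these compounds, it remains open whether a phenyl ring with no added group, or one carrying a nitrile, a methoxy group or a carboxylic acid in place of trifluoromethyl, would keep this reading. All three compounds share the same core, so it is also unknown whether the exchange of 3,4-dichlorophenyl for 3-(trifluoromethyl)phenyl would have a similar effect on a different core.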